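The source may hold more compounds than are shown below. What is called first, only, known or untested is meant among the compounds shown, and "the series" means these compounds.

Measured so far:
- compound 1, `CN(C(=O)CCc1ccccc1)c1ccc2[nH]c(-c3n[nH]c4ccccc34)cc2n1`: 7380 nM
- compound 2, `COc1ccc(S(=O)(=O)N(C)c2ccc3[nH]c(-c4n[nH]c5ccccc45)cc3n2)cc1OC`: 10100 nM

Both numbers come from a functional assay on KB cells (Homo sapiens) for antiproliferative activity, read by MTT assay, with a stated time of 72 h; a higher number here means a weaker inhibitor, a lower number a stronger inhibitor. Compound 1 gives 7380 nM and compound 2 gives 10100 nM. The two values lie within the usual scatter of repeated measurements of each other, so neither compound can be called the stronger inhibitor on this evidence; compound 1 simply has the lower of the two numbers.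

Compound 3, `CN(C(=O)Nc1ccccc1)c1ccc2[nH]c(-c3n[nH]c4ccccc34)cc2n1`, has not yet been measured. It keeps the shared core of compound 1 and differs in one place: anilino in place of phenethyl on a carbonyl carbon. Put another way, phenethylcarbonyl becomes phenylcarbamoyl on the carbonyl carbon that sits on the amide-type nitrogen.

Within the data shown here, no pair of measured compounds separated by a single change is available, so the size of this step cannot be read from anything measured. The expectation is a step of a 1.1-fold higher number from compound 1 to compound 3 (0.04 log units; within the scatter), that is, none beyond the scatter. Compound 3 is therefore estimated at 8000 nM, with a range from 2500 nM to 25000 nM.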

Compound 3, half-maximal inhibitory concentration: 32 nM
Beside the measured number, compound 3's estimate is 250-fold (2.40 log units) above it; the whole stated range lies above it.
By their numbers in this assay, from the lowest: compound 3; then compounds 1 and 2 (each within the scatter of the next).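

In this assay, the group on this carbonyl carbon turns out to matter greatly: anilino in place of phenethyl gives a 230-fold lower number from compound 1 to compound 3 (2.36 log units; beyond the scatter), the first single-change step available in this set. Both groups carry a six-membered aromatic ring of carbon only, so the step goes with what else differs: anilino brings a nitrogen and a hydrogen-bond donor that phenethyl does not have, and it is one heavy atom smaller. Nothing measured here explains why the step is so large.

A single pair cannot separate the role of the nitrogen from that of the chain length. Phenoxy on the same carbonyl carbon would test the ring without that nitrogen, and benzylamino would test the nitrogen with a longer chain to the ring.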